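This account rests on a few compounds, and the source may have more. Where it says the series, first, only, none or still open, it means among the compounds named here.

Series notes. Among the compounds with values here, in a physicochemical assay for lipophilicity, measured as octanol-water partition (a lower number here means a more polar compound, a higher number a more lipophilic compound), compound 1 `O=C(COc1cccc2ccccc12)N/N=C/c1cccc(O)c1` gives 3.73, the lowest of the three numbers so far. Within the data shown here, compound 2 `O=C(COc1cccc2ccccc12)N/N=C/c1cccc([N+](=O)[O-])c1` gives 3.97, and the step of a number 0.24 log units higher from compound 1 to compound 2 (within the scatter) is the only measured change on the group attached to the carbon with a double bond to nitrogen. Compound 3 `C/C(=N\NC(=O)COc1cccc2ccccc12)c1ccc(O)cc1` gives 4.44, beyond the scatter from compound 1, but it differs from compound 1 in more than one place, so no single step can be read from that pair. Compound 4 `COc1ccc(/C=N/NC(=O)COc2cccc3ccccc23)cc1` carries the change (4-methoxyphenyl in place of 3-hydroxyphenyl on a carbon with a double bond to nitrogen). Among the measured compounds shown here, no measured pair removes the hydrogen-bond donor on that group, so the size is uncertain; an upward step of a number 0.67 log units higher from compound 1 to compound 4 (beyond the scatter) is expected. Compound 4 is therefore estimated at 4.4, between 4 and 4.8.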

Compound 4, partition coefficient: 3.77
For compound 4 the middle estimate is 0.63 log units above the measured one; measured number outside the range, below it.
By their numbers in this assay, from the lowest: compounds 1, 4 and 2 (each within the scatter of the next); then compound 3.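

In this assay, 4-methoxyphenyl in place of 3-hydroxyphenyl on a carbon with a double bond to nitrogen gives a number 0.04 log units higher from compound 1 to compound 4 (within the scatter), so the group's count of hydrogen-bond donors can go from 1 to 0 without a step beyond the scatter. With a number 0.24 log units higher from compound 1 to compound 2 (within the scatter), both single-place changes read at this place now lie within the scatter. No evidence is available that accounts for this result.

From the compounds shown here alone, whether a carboxylic acid or an amine at this place would give a step beyond the scatter stays open. The number of compound 3 cannot be read as a single step from compound 1.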